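The source may hold more compounds than are shown below. What is called first, only, known or untested is meant among the compounds shown, and "the series" means these compounds.

Working notes on the series. Two compounds carry numbers in a functional assay on NCI-H522 cells (Homo sapiens) for antiproliferative activity, read by sulforhodamine B assay, with a stated time of 48 h; a lower number here means a stronger inhibitor of growth, a higher number a weaker inhibitor of growth. Compound 1 `COc1ccc(OC)c(/C=C/c2nnc(Nc3ccc(Cl)cc3)o2)c1` gives 7130 nM in this assay. Compound 2 `COc1ccc(OC)c(/C=C/C(=O)N/N=C/c2ccc(Cl)cc2)c1` gives 29.2 nM in this assay, the lowest of the two numbers; its nearest neighbour is compound 1, whose number lies far higher, well beyond the usual scatter. Among the measured compounds shown here, since the two compounds differ in more than one place, their pair yields no single-point step, and only the two values themselves can be read.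

Compound 3 `COc1ccc(OC)c(/C=C/C(=O)N/N=C/c2ccccc2)c1` is the next compound to be measured in this assay. It differs from compound 2 by hydrogen in place of chloro on an aromatic carbon of the six-membered aromatic ring of carbon only, para to a large group; read one bond further out, the 4-chlorophenyl becomes phenyl. For the measured compounds named here, no step of this kind is available within the measured compounds, so the expectation rests on the structural change alone. The expected step of a 2.4-fold higher number from compound 2 to compound 3 (0.38 log units; beyond the scatter) is toward a somewhat higher number, modest and near the edge of the scatter. Compound 3 is expected to give about 70 nM in this assay, within an estimated range from 15 nM to 350 nM.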

Compound 3, concentration for 50% growth inhibition: 1570 nM
Compound 3: middle estimate off by 22-fold (1.35 log units), on the low side, and the stated range ends below it.
By their numbers in this assay, from the lowest: compound 2; then compound 3; then compound 1.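

In this assay, among the compounds shown here, hydrogen in place of chloro on an aromatic carbon of the six-membered aromatic ring of carbon only, para to a large group, gives a 54-fold higher number from compound 2 to compound 3 (1.73 log units; beyond the scatter), the first single-point step and a large one. The low number of compound 2 therefore depends on this one substituent: losing one heavy atom, a chlorine that brings no ring, no hydrogen-bond donor or acceptor and no net charge, takes the series well beyond the usual scatter of the assay. No measurement at hand accounts for the size of this step, so it stands as an observation for this single pair of compounds.

The compounds shown leave open whether the low number is particular to chlorine or would also hold with another group at the same place, such as fluoro, bromo, methoxy or an amine. They also leave open whether the same exchange of 4-chlorophenyl for phenyl would give a step of similar size on the core of compound 1, and whether the chloro would matter as much elsewhere on the ring.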